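Aryl swap on the core: from compound 3 to compound 4

A few compounds are considered here, and "the series" means these few. Any claim that something is new, unique, unknown or untested is made for them only; others in the source may bear on it.

Compound 3 `O=C(O)Cc1sc(C(c2ccccc2)c2ccccc2)nc1-c1ccc(C(F)(F)F)cc1` carries a 4-(trifluoromethyl)phenyl on the shared core. Among the compounds with values here, in an in vitro functional assay on HEK285-7 cells for antagonist activity at prostaglandin D2 receptor 2 (Homo sapiens), read by BRET and beta-arrestin recruitment (on this read-out lower numbers stand for stronger inhibition and higher numbers for weaker inhibition), compound 3 gives only a limit, > 100000 nM, and is the one value at the limit of > 100000 nM in this assay, at which 1 of the 3 values shown sits. The fluorinated analogues stand far apart: compound 1 `O=C(O)Cc1sc(C(c2ccccc2)c2ccccc2)nc1-c1ccc(F)cc1` gives 77 nM in this assay, and compound 2 `O=C(O)Cc1sc(C(c2ccccc2)c2ccccc2)nc1-c1cccc(F)c1` gives 29 nM. The steps to compound 3 are an at least 1200-fold higher number from compound 1 to compound 3 (3.11 log units; beyond the scatter) and an at least 3400-fold higher number from compound 2 to compound 3 (3.53 log units; beyond the scatter), both large, whereas between the two fluoro compounds the step is a 2.7-fold lower number from compound 1 to compound 2 (0.42 log units; beyond the scatter), modest. Compound 4 `COc1ccc(OC)c(-c2nc(C(c3ccccc3)c3ccccc3)sc2CC(=O)O)c1` is the unmeasured analogue with 2,5-dimethoxyphenyl in place of 4-(trifluoromethyl)phenyl on an aromatic carbon. Within the data shown here, no measured step introduces methoxy groups, so the only guide is that the single member at the limit, compound 3, is the trifluoromethyl one, while both fluoro compounds measure well. For compound 4 a large downward step in this assay is therefore expected, an at least 330-fold lower number from compound 3 to compound 4 (2.52 log units; beyond the scatter), back toward the region of compounds 1 and 2, with wide uncertainty. Compound 4 is estimated at 300 nM, within a range of 30 nM to 5000 nM.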

Compound 4, half-maximal inhibitory concentration: > 100000 nM
Compound 4 ended at the assay's limit; the forecaster's own chance of this, stated with the estimate: 15%; middle value at least 330-fold (2.52 log units) from the limit.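

At this position, on an aromatic carbon next to the ring nitrogen, the loss of a measurable value in this assay is no longer tied to 4-(trifluoromethyl)phenyl alone, as a second aryl group with different atoms now reaches the same limit: the limit of > 100000 nM in this assay, at which 2 of the 4 values shown sit.

Replacing either fluorophenyl with 2,5-dimethoxyphenyl gives an at least 3400-fold higher number from compound 2 to compound 4 (3.53 log units; beyond the scatter) and an at least 1200-fold higher number from compound 1 to compound 4 (3.11 log units; beyond the scatter), so among the four compounds shown, only the two fluorophenyl compounds give a measured value. The step between the two compounds at the limit cannot be read, so no order can be set between 2,5-dimethoxyphenyl and 4-(trifluoromethyl)phenyl.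

As far as these compounds go, it remains open whether a single methoxy group would suffice to reach the limit or whether both are needed. From the compounds shown here alone, it is also open whether a chlorophenyl or a methylphenyl would stand with the fluorophenyl compounds or at the limit.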